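A Methyl-for-Chloro Swap Tested Against Microsomal Stability

The source may report more compounds than this note shows. Statements on the series, on what has been measured and on what is new or still open speak of the compounds shown alone.

Three compounds were measured in an ADME assay on microsomes from liver (Rattus norvegicus) for metabolic stability, read by LC-MS, using NADPH, with a stated time of 10 min, tested at 0.5 uM; on this read-out lower numbers stand for a less stable compound and higher numbers for a more stable compound. Compound 3 `CC(=O)Nc1cc(-c2ccc(OC[C@@H](N)CC(C)C)c(Cl)c2)ccn1` gives 100%. Compound 1 `CC(=O)Nc1cc(-c2ccc(OC[C@@H](N)CC(C)C)c(C)c2)ccn1` gives 99%. The change from compound 3 to compound 1 is methyl in place of chloro on an aromatic carbon, and it produced a number 1 percentage points lower from compound 3 to compound 1 (within the scatter). Compound 2 `COC(=O)Nc1cc(-c2cc(Cl)c(OC[C@@](C)(N)CC(C)C)cn2)ccn1` gives 99% in this assay; the difference between the cores of compound 2 and compound 3 is not broken down here. Compound 4 `COC(=O)Nc1cc(-c2cc(C)c(OC[C@@](C)(N)CC(C)C)cn2)ccn1` has not yet been measured. Its difference from compound 2 is methyl in place of chloro on an aromatic carbon, the same kind of change as from compound 3 to compound 1, though here the place is on a six-membered aromatic ring with 1 nitrogen, ortho to a (2-amino-2,4-dimethylpentyl)oxy group and opposite the ring nitrogen, whereas in the earlier pair it is on a ring of carbon only, ortho to a (2-amino-4-methylpentyl)oxy group. The step expected here is no change at the digits printed from compound 2 to compound 4 (within the scatter), because the same kind of change gave a number 1 percentage points lower from compound 3 to compound 1 (within the scatter). Compound 4 is therefore estimated to give 99%, within 94% to 100%.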

Compound 4, percent of the compound remaining: 100%
The estimate for compound 4 lay 1 percentage points below the measured number; the range from low to high includes it.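

In this assay, methyl in place of chloro on an aromatic carbon gave a number 1 percentage points higher from compound 2 to compound 4 (within the scatter), and set beside the earlier case, the two cores agree: the same change on two cores in this assay, a number 1 percentage points lower (within the scatter) from compound 3 to compound 1 and a number 1 percentage points higher (within the scatter) from compound 2 to compound 4, 2 percentage points apart, within the scatter of two such steps. On these two cores, then, the change carried over without a step beyond the scatter, and the opposite signs of the two steps carry no meaning. This does not show that the change is neutral across the series, since all four compounds stand close to full retention, and two pairs at that level say nothing about a compound of which much less remains.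

The compounds shown leave open how the same change reads on a core that loses a clear share of its material over the stated time. They also leave open how other groups at this place, such as fluoro, methoxy or trifluoromethyl, would compare with chloro and methyl on the pyridine-type core of compound 2 and on the core of compound 3.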